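A few compounds are considered here, and "the series" means these few. Any claim that something is new, unique, unknown or untested is made for them only; others in the source may bear on it.

Measured so far:
Compound 1 `CC(C)(C)OC(=O)NCCNC(=O)CN1CN(c2ccccc2)C2(CCN(C(=O)c3ccc(C(C)(C)C)cc3)CC2)C1=O`: 10900 nM
Compound 2 `CC(C)(C)c1ccc(C(=O)N2CCC3(CC2)C(=O)N(CC(=O)NCCCCNS(C)(=O)=O)CN3c2ccccc2)cc1`: 4500 nM

Going by the values given here, in an assay on HEK293 cells for displacement of a labelled ligand from NPC1-like intracellular cholesterol transporter 1 (Homo sapiens) (a higher number here means a weaker inhibitor, a lower number a stronger inhibitor), compound 2 gives the lowest of the two numbers, with compound 1 the only neighbour: a 2.4-fold lower number from compound 1 to compound 2 (0.38 log units; beyond the scatter). Compound 3 `CC(C)(C)c1ccc(C(=O)N2CCC3(CC2)C(=O)N(CC(=O)N2CCNCC2)CN3c2ccccc2)cc1` differs from compound 2 by piperazin-1-yl in place of (4-(methanesulfonamido)butyl)amino on a carbonyl carbon. Among the compounds with values here, only one measured step exists, and it altered the far end of the chain rather than replacing the whole amino substituent, so it bears on this change only loosely; it was modest and does not indicate the direction here. The estimate is therefore a step of a 1.3-fold higher number from compound 2 to compound 3 (0.12 log units; within the scatter), with wide uncertainty. Compound 3 is expected to give 6000 nM, between 1500 nM and 25000 nM.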

Compound 3, half-maximal inhibitory concentration: 22000 nM
For compound 3 the middle estimate is 3.7-fold (0.56 log units) below the measured one; the measured number falls inside the stated range.
By their numbers in this assay, from the lowest: compound 2; then compounds 1 and 3 (each within the scatter of the next).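

In this assay, piperazin-1-yl in place of (4-(methanesulfonamido)butyl)amino on this carbonyl carbon gives a 4.9-fold higher number from compound 2 to compound 3 (0.69 log units; beyond the scatter) and so shows that replacing the whole amino substituent also moves the number. Against the (2-((tert-butoxycarbonyl)amino)ethyl)amino of compound 1, the same group gives a 2.0-fold higher number from compound 1 to compound 3 (0.30 log units; within the scatter) and leaves only compound 2 standing apart. No supporting evidence explains this result. Still open, going by these compounds, is how morpholin-4-yl or 4-methylpiperazin-1-yl would compare with piperazin-1-yl, and whether a longer chain ending in methanesulfonamido would lower the number further.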